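This account rests on a few compounds, and the source may have more. Where it says the series, first, only, none or still open, it means among the compounds named here.

Of the compounds shown here, three have been read in an ADME assay on Caco-2 cells (Homo sapiens) for permeability, read by LC-MS, in the apical to basolateral direction, with a stated time of 2 h, tested at 2 uM; on this read-out lower numbers stand for lower permeability and higher numbers for higher permeability. Compound 1 `CCOc1ccccc1-c1ccc(-c2nc3cncc(Cl)c3c(N[C@H](CC)C(N)=O)c2C#N)cc1` gives 17 nm/s, compound 2 `CC[C@@H](Nc1c(C#N)c(-c2ccc(-c3ccc(OC)cc3)cc2)nc2cnccc12)C(N)=O` gives 114 nm/s, and compound 3 `CC[C@@H](Nc1c(C#N)c(-c2ccc(-c3cccc(Cl)c3)cc2)nc2cnccc12)C(N)=O` gives 37 nm/s. Compound 3 therefore holds the middle of the three numbers, above compound 1 and below compound 2, with both gaps beyond the usual scatter.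

The next compound is compound 4 `CC[C@@H](Nc1c(C#N)c(-c2ccc(-c3cccc(OC)c3)cc2)nc2cnccc12)C(N)=O`, which differs from compound 3 in one place: methoxy in place of chloro on an aromatic carbon. Methoxy stands in place of chloro on an aromatic carbon, meta to a large group, so 3-chlorophenyl becomes 3-methoxyphenyl.

Among the measured compounds shown here, the one measured step that bears on this is a 3.1-fold lower number from compound 2 to compound 3 (0.49 log units; beyond the scatter). That step also replaces a methoxy-bearing ring with a chloro-bearing one, and the number falls, but the methoxy of compound 2 does not sit where the chloro of compound 3 sits, so it is only a partial guide. For the measured compounds named here, with compound 2 at 114 nm/s, a modest move to a higher number in this assay is expected, probably smaller than that step, and the single precedent leaves the expectation wide. The expected change is a 2.0-fold higher number from compound 3 to compound 4 (0.31 log units; beyond the scatter). The estimate for compound 4 is 75 nm/s, with an expected range from 30 nm/s to 180 nm/s.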

Compound 4, apparent permeability: 104 nm/s
Compound 4: middle estimate off by 1.4-fold (0.14 log units), on the low side; the measured number falls inside the stated range.
By their numbers in this assay, from the lowest: compound 1; then compound 3; then compounds 4 and 2 (each within the scatter of the next).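

In this assay, methoxy in place of chloro at one fixed place on the ring gives a 2.8-fold higher number from compound 3 to compound 4 (0.45 log units; beyond the scatter) and so reads the change of group alone, whereas the earlier 3.1-fold lower number from compound 2 to compound 3 (0.49 log units; beyond the scatter) changed the group and its place together. Moving the methoxy from the 4-methoxyphenyl to the 3-methoxyphenyl arrangement gives a 1.1-fold lower number from compound 2 to compound 4 (0.04 log units; within the scatter) and so leaves the two methoxy placements unresolved on this read-out, which means that among compounds 2, 3 and 4 the number follows the identity of the group and not its place, with the one chloro compound standing apart from the two methoxy compounds. Nothing given here explains why the chloro and methoxy compounds differ on this read-out.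

The compounds shown put only chloro and methoxy at this place, so it remains open how an amine, a hydroxyl or a longer ether chain such as ethoxy would read there. As far as these compounds go, it also remains open whether the gap between methoxy and chloro would hold at another place on the ring, since it rests on a single matched pair.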